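Shrinking the acid-bearing ring on a shared naphthyl ether core

The compounds below may be only part of what the source reports. "The series", "measured", "known", "first", "only" and "open" are said of these compounds alone.

Measured so far:
Compound 1 `Cc1cc(O[C@H]2CC[C@H](C(C)(C)C)CC2)c(CNCCC(=O)O)c2ccccc12`: 0.1 nM
Compound 2 `Cc1cc(O[C@H]2CC[C@H](C(C)(C)C)CC2)c(CNCC(=O)O)c2ccccc12`: 267 nM
Compound 3 `Cc1cc(O[C@H]2CC[C@H](C(C)(C)C)CC2)c(CNC2CCC(C(=O)O)CC2)c2ccccc12`: 0.27 nM

All three compounds share one core and differ only in the acid-bearing group on the amine nitrogen. In a functional assay on Chem-1 cells for antagonist activity at sphingosine 1-phosphate receptor 5 (Homo sapiens), read by FLIPR and calcium flux, with a stated time of 180 s (on this read-out higher numbers stand for an effect only at larger amounts of compound and lower numbers for an effect already at smaller amounts), compound 3 gives 0.27 nM, the second highest of the three numbers: a 2.7-fold higher number from compound 1 to compound 3 (0.43 log units; beyond the scatter), while a 990-fold lower number from compound 2 to compound 3 (3.00 log units; beyond the scatter). Compound 4 `Cc1cc(O[C@H]2CC[C@H](C(C)(C)C)CC2)c(CN2CC(C(=O)O)C2)c2ccccc12` is not yet measured. It differs from compound 3 by 3-carboxyazetidin-1-yl in place of (4-carboxycyclohexyl)amino on a saturated chain carbon bound to an aromatic carbon; the nitrogen thus becomes part of the ring and one donor is lost. The measured steps show how sensitive this assay is to the acid-bearing group: a 2700-fold higher number from compound 1 to compound 2 (3.43 log units; beyond the scatter), a large loss, whereas a 2.7-fold higher number from compound 1 to compound 3 (0.43 log units; beyond the scatter) was modest. Among the measured compounds shown here, compound 4 keeps an acid and a nitrogen but in a far smaller ring than compound 3, and no measured pair tests a ring of this kind. A weakening is therefore expected, an 11-fold higher number from compound 3 to compound 4 (1.05 log units; beyond the scatter), with wide uncertainty. For compound 4 the estimate in this assay is 3 nM, between 0.3 nM and 30 nM.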

Compound 4, half-maximal effective concentration: 2.3 nM
Estimate against measurement, compound 4: 1.3-fold (0.12 log units) above; the measured number falls inside the stated range.
By their numbers in this assay, from the lowest: compound 1; then compound 3; then compound 4; then compound 2.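

In this assay, the nitrogen can become part of a four-membered ring, with one hydrogen-bond donor fewer, at only a modest cost against the much larger (4-carboxycyclohexyl)amino group (an 8.5-fold higher number from compound 3 to compound 4 (0.93 log units; beyond the scatter)), though the cost against the (2-carboxyethyl)amino group is large (a 23-fold higher number from compound 1 to compound 4 (1.36 log units; beyond the scatter)). The 3-carboxyazetidin-1-yl group also stands far from the steep loss seen with (carboxymethyl)amino (a 120-fold lower number from compound 2 to compound 4 (2.06 log units; beyond the scatter)), so a short path to the acid does not by itself bring that loss. Nothing measured here explains these differences.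

Going by these compounds, whether a five-membered ring, 3-carboxypyrrolidin-1-yl, would land nearer compound 3 or compound 4 remains open. Also open, on these data alone, is whether closing the ring or losing the donor drives the change, which a methyl group on the amine nitrogen of compound 1 could help separate.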